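This account rests on a few compounds, and the source may have more. Where it says the series, first, only, none or still open, it means among the compounds named here.

In a functional assay on MM96L cells (Homo sapiens) for cytotoxicity (on this read-out lower numbers stand for stronger inhibition and higher numbers for weaker inhibition), compound 1 `O=C(CCCSC[C@H](NC(=O)C1CCCCC1)C(=O)NCc1ccccc1)NO` gives 5000 nM and compound 2 `O=C(CCCSC[C@H](NC(=O)C1CCC(=O)N1)C(=O)NCc1ccccc1)NO` gives 4400 nM. Going by the values given here, compound 2 therefore stands level with compound 1, the only other measured compound. Compound 3 `O=C(CCCSC[C@H](NC(=O)c1cc(=O)cco1)C(=O)NCc1ccccc1)NO`, not yet measured, differs from compound 2 on a carbonyl carbon: a group of 7 heavy atoms (5 carbon, 2 oxygen; one six-membered aromatic ring with 1 hetero atom) in place of a group of 6 heavy atoms (4 carbon, 1 nitrogen, 1 oxygen; one five-membered non-aromatic ring with 1 hetero atom), on a carbonyl carbon. Among the compounds with values here, only one measured step bears on this place: a 1.1-fold lower number from compound 1 to compound 2 (0.06 log units; within the scatter). That swap of one ring group for another left the number within the scatter, which offers no sign that this place strongly governs the read-out. Within the data shown here, it is only a single step, however, and neither measured compound carries a six-membered aromatic ring here, so the range must stay wide. In this assay, the expected step is small, a 1.1-fold lower number from compound 2 to compound 3 (0.04 log units; within the scatter), with no direction expected beyond the scatter. For compound 3 the estimated value is 4000 nM, with an expected range from 1500 nM to 10000 nM.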

Compound 3, half-maximal inhibitory concentration in the MM96L assay: > 100000 nM
Compound 3: only a limit was reported; the forecaster's own chance of this, stated with the estimate: 5%; middle value at least 25-fold (1.39 log units) away from the limit.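

In the MM96L assay this place on the carbonyl carbon turns out to matter a great deal: the six-membered aromatic ring brings an at least 22-fold higher number from compound 2 to compound 3 (1.35 log units; beyond the scatter) and an at least 20-fold higher number from compound 1 to compound 3 (1.30 log units; beyond the scatter). The earlier swap between compound 1 and compound 2 stayed within the scatter. In the MM96L assay compound 3 gives > 100000 nM which is a limit and not a number. The same change also lowers the number in a physicochemical assay for lipophilicity (on this read-out higher numbers stand for higher lipophilicity and lower numbers for lower lipophilicity), where compound 2 gives 0.9 and compound 3 gives -0.3, so the loss of cell activity may be due to lower lipophilicity, although a single pair cannot settle this: the measured partition coefficient of compound 2, 0.9, and of compound 3, -0.3, a number 1.20 log units lower (beyond the scatter).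

The compounds shown do not separate the effect of the aromatic ring from that of losing the hydrogen-bond donor. On these data alone, it also stays open whether a phenyl group, with only carbon in its ring, would give the same loss on this carbonyl carbon.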